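Replacing the Chain-End Bromine of Compound 2

This account rests on a few compounds, and the source may have more. Where it says the series, first, only, none or still open, it means among the compounds named here.

Compound 1 `COc1ccc(N(C)c2ccnc(Cl)n2)cc1OCCCCBr`: 992 nM
Compound 2 `COc1ccc(N(C)c2ccnc(Cl)n2)cc1OCCCCCBr`: > 10000 nM

In a functional assay on MDA-MB-231 cells (Homo sapiens) for antiproliferative activity, read by MTT assay, with a stated time of 48 h (on this read-out lower numbers stand for stronger inhibition and higher numbers for weaker inhibition), compound 1 gives 992 nM. Compound 2 is reported as > 10000 nM, which is a limit of the assay and not a number. Among the measured compounds shown here, the only measured step is an at least 10-fold higher number from compound 1 to compound 2 (1.00 log units; beyond the scatter), and it lies beyond the scatter. Compound 3 `COc1ccc(N(C)c2ccnc(Cl)n2)cc1OCCCCC[Se]C#N` keeps the chain of compound 2 and alters its end: a group of 3 heavy atoms (1 carbon, 1 nitrogen, 1 selenium; no ring) in place of one bromine atom, on a saturated chain carbon, five bonds along the chain from an oxygen on an aromatic ring. That step concerns the chain and leaves the bromine in place, so no measurement covers this exchange directly and its size stays uncertain. Compound 1 at 992 nM shows that a measurable value is possible in this family, so a lower number is expected, though with a wide margin. The expected move is an at least 6.6-fold lower number from compound 2 to compound 3 (0.82 log units; beyond the scatter). For compound 3 the estimated value is 1500 nM, with an expected range from 200 nM to 9000 nM.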

Compound 3, half-maximal inhibitory concentration: > 10000 nM
Compound 3: only a limit was reported; the forecaster's own chance of this, stated with the estimate: 15%; middle value at least 6.6-fold (0.82 log units) away from the limit.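

Placing the selenium-bearing group on a saturated chain carbon, five bonds along the chain from an oxygen on an aromatic ring, does not bring back a measurable value in this assay, and compound 3 stands at > 10000 nM, which is a limit of the assay and not a number. Compound 2 and compound 3 are both limits, and the step between them cannot be read. The one readable new step is an at least 10-fold higher number from compound 1 to compound 3 (1.00 log units; beyond the scatter), and it ends at the same limit as compound 2: the limit of > 10000 nM in this assay, at which 2 of the 3 values shown sit.

As far as these compounds go, whether the selenium-bearing group would give a measurable value on the chain of compound 1 stays open. Also open, from the compounds shown here alone, is how an amine or a carboxylic acid at the chain end would read in this assay.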